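Amide aryl swap in a series without measurable cytotoxicity

The compounds below may be only part of what the source reports. "The series", "measured", "known", "first", "only" and "open" are said of these compounds alone.

Three compounds of the shared core have been run in an ADME assay on NCM460 cells (Homo sapiens) for cytotoxicity, read by MTT assay, with a stated time of 72 h; on this read-out higher numbers stand for weaker inhibition and lower numbers for stronger inhibition. Compound 1 `CCCCCN1C(=O)C/C(=C\c2cccc(C(=O)Nc3ccc(C)cc3)c2)C1=O` gives > 100000 nM in this assay, which is a limit of the assay rather than a number. Compound 2 `Cc1cccc(NC(=O)c2cccc(/C=C3\CC(=O)N(c4ccccc4)C3=O)c2)c1` gives > 100000 nM in this assay, again a limit. Compound 3 `Cc1ccc(N2C(=O)C/C(=C\c3cccc(C(=O)Nc4ccc(Cl)cc4)c3)C2=O)cc1` gives > 100000 nM in this assay, also a limit. Compound 2 therefore stands where every measured member stands, at the limit of > 100000 nM in this assay, at which 3 of the 3 values shown sit, and no ordering among the three can be drawn.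

Among the measured compounds shown here, no pair of measured compounds differs in one place, so no step size is known from the data. Compound 4 `O=C(Nc1ccc(F)cc1)c1cccc(/C=C2\CC(=O)N(c3ccccc3)C2=O)c1` has not yet been measured in this assay. Relative to compound 2 the change is on an amide-type nitrogen: 4-fluorophenyl in place of 3-methylphenyl on an amide-type nitrogen.

Because compounds 1, 2 and 3 all sit at the limit of > 100000 nM in this assay, at which 3 of the 3 values shown sit, no step beyond the scatter is expected for compound 4 in this assay, and another limit is the most likely outcome. Compound 4 is expected to give 150000 nM in this assay, with a range from 60000 nM to 500000 nM. The expected step that the limit leaves unreadable from compound 2 to compound 4 is thus none beyond the scatter.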

Compound 4, half-maximal inhibitory concentration: > 100000 nM
Compound 4: only a limit was reported (the forecaster's own chance of this, stated with the estimate: 85%); the middle value does not contradict the limit.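

No step can be read between compound 2 and compound 4, since both values are limits: the limit of > 100000 nM in this assay, at which 4 of the 4 values shown sit.

The compounds shown leave open whether any change on the shared core would give a measured number rather than a limit in this assay.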